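The compounds below may be only part of what the source reports. "The series", "measured", "known", "first", "only" and "open" are said of these compounds alone.

Among the compounds with values here, compound 1 `CC(C)Oc1ccc(C(C)(C)O)cc1-c1cn(C)c(=O)c2[nH]c(C(=O)NCc3ccc(C(=O)NO)cc3)cc12` stands at the top of the three numbers so far in a functional assay on MV4-11 cells (Homo sapiens) for antiproliferative activity, read by CCK-8 assay, with a stated time of 72 h (on this read-out lower numbers stand for stronger inhibition and higher numbers for weaker inhibition), where compound 1 gives 350 nM. Compound 2 `CC(C)Oc1ccc(C(C)(C)O)cc1-c1cn(C)c(=O)c2[nH]c(C(=O)NCCCCCCC(=O)NO)cc12` gives 160 nM in this assay, and compound 3 `Cn1cc(-c2cccc(Cl)c2)c2cc(C(=O)NCc3ccc(C(=O)Nc4ccccc4N)cc3)[nH]c2c1=O` gives 190 nM; the gap from compound 1 to compound 3 lies within the scatter, so no order between those two can be read. Within the data shown here, the only single-point step measured so far is a 2.2-fold lower number from compound 1 to compound 2 (0.34 log units; beyond the scatter), and it concerns the hydroxamate-bearing chain, not the ether substituent on the aryl ring.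

Compound 4 `Cn1cc(-c2cc(C(C)(C)O)ccc2Oc2ccc(F)cc2F)c2cc(C(=O)NCc3ccc(C(=O)NO)cc3)[nH]c2c1=O` differs from compound 1 by 2,4-difluorophenyl in place of isopropyl on an oxygen on an aromatic ring. Among the measured compounds shown here, no measured pair changes the group on that oxygen; compound 3 differs from compound 1 in several places at once, so its value bears only loosely on this step. For the measured compounds named here, the series therefore gives no direct precedent for the change, and the expectation for compound 4 is a step of no clear direction, most likely within the scatter, which the estimated step of a 1.2-fold lower number from compound 1 to compound 4 (0.07 log units; within the scatter) reflects. Compound 4 is estimated at 300 nM in this assay, with a range from 100 nM to 900 nM.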

Compound 4, half-maximal inhibitory concentration: 190 nM
For compound 4 the middle estimate is 1.6-fold (0.20 log units) above the measured one; the range from low to high includes it.
By their numbers in this assay, from the lowest: compounds 2, 3, 4 and 1 (each within the scatter of the next, the first and the last beyond it).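

The oxygen on the aromatic ring now has its first measured variation. In this assay, within the data shown here, the isopropyl-to-2,4-difluorophenyl swap gives a 1.8-fold lower number from compound 1 to compound 4 (0.27 log units; within the scatter), so exchanging a group of 3 heavy atoms with no ring for one of 8 heavy atoms carrying a six-membered aromatic ring and two fluorines produces no step that can be read beyond the scatter on this hydroxamate-bearing benzyl amide. The measurement therefore shows that, on this read-out, this position accepts an aryl ether as well as an alkyl ether, at least for this one pair. Nothing available on the compounds explains this outcome.

Among these compounds, the single pair cannot separate the contribution of the ring from that of the fluorines, and an unsubstituted phenoxy, a 2-pyridyloxy or a free hydroxyl at the same place would address that question and test how far the position's latitude extends. Among the compounds shown here, whether 2,4-difluorophenoxy behaves the same way with the 5-(hydroxycarbamoyl)pentyl chain of compound 2 also remains open, as no pair carries this ether on that chain.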